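The source may report more compounds than this note shows. Statements on the series, on what has been measured and on what is new or still open speak of the compounds shown alone.

In an ADME assay on Vero cells (Chlorocebus sabaeus) for cytotoxicity, read by MTT assay, with a stated time of 72 h (a lower number here means a stronger inhibitor, a higher number a weaker inhibitor), compound 1 `c1ccc(-c2nnc(-c3ccc(-n4cccc4)cc3)o2)cc1` gives 250000 nM. Within the data shown here, only one other number exists in this assay: compound 2 `O=[N+]([O-])c1cccc(-c2nnc(-c3ccc(-n4cccc4)cc3)o2)c1` gives 251000 nM, and the step of a 1.0-fold higher number from compound 1 to compound 2 (0.00 log units; within the scatter) leaves the two values indistinguishable. Compound 3 `Cc1ccc(C)n1-c1ccc(C(=O)N/N=C/c2ccccc2)cc1` has no result in this assay, recorded as "not determined" (no result reported). Compound 4 `Clc1ccc(-c2nnc(-c3ccc(-n4cccc4)cc3)o2)cc1` differs from compound 1 by chloro in place of hydrogen on an aromatic carbon. Among the measured compounds shown here, the single measured step that bears on a substitution of this kind on the same ring is a 1.0-fold higher number from compound 1 to compound 2 (0.00 log units; within the scatter), which produced no movement beyond the scatter. On that basis the estimated step of no change at the digits printed from compound 1 to compound 4 (within the scatter) is expected to be none beyond the scatter. Compound 4 is therefore expected to give about 250000 nM in this assay, within a range from 150000 nM to 420000 nM.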

Compound 4, half-maximal inhibitory concentration: 253000 nM
Compound 4: middle estimate off by 1.0-fold (0.01 log units), on the low side, and the stated range covers the measured number.
By their numbers in this assay, from the lowest: compounds 1, 2 and 4 (each within the scatter of the next).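

In this assay, chloro on an aromatic carbon para to a large group gives a 1.0-fold higher number from compound 1 to compound 4 (0.01 log units; within the scatter) and so leaves the number within the scatter. The earlier step showed this only for nitro on this ring, whereas the phenyl to 4-chlorophenyl change now adds a single halogen atom to that picture. Nothing available explains why the number holds. On these data alone, whether an amine, a carboxylic acid or a methoxy group at this place would shift the number beyond the scatter stays open. So does the effect of changing the pyrrole-bearing side of the shared core.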